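The source may hold more compounds than are shown below. What is called first, only, known or untested is meant among the compounds shown, and "the series" means these compounds.

Working notes on the series. Of the compounds shown here, three sharing one core have been measured in an assay on Prostate gland for inhibition of steroid 5-alpha-reductase (Rattus norvegicus); a lower number here means a stronger inhibitor, a higher number a weaker inhibitor. Compound 1 `CCCC(C)n1ccc2cc(/C(C)=C/C(=O)Nc3ccccc3OCCCC(=O)O)ccc21` gives 7.8 nM. Compound 2 `CCCC(C(C)C)n1ccc2cc(/C(C)=C/C(=O)Nc3ccccc3OCCCC(=O)O)ccc21` gives 7.2 nM. Compound 3 `CCCCC(CC)n1ccc2cc(/C(C)=C/C(=O)Nc3ccccc3OCCCC(=O)O)ccc21` gives 7.1 nM. Compound 3 sits with the other two inside the scatter, as shown by a 1.1-fold lower number from compound 1 to compound 3 (0.04 log units; within the scatter) and a 1.0-fold lower number from compound 2 to compound 3 (0.01 log units; within the scatter); the step of a 1.1-fold lower number from compound 1 to compound 2 (0.03 log units; within the scatter) is likewise within it. Compound 4 `CCCCC(CCCC)n1ccc2cc(/C(C)=C/C(=O)Nc3ccccc3OCCCC(=O)O)ccc21` differs from compound 3 by ethyl in place of hydrogen on a saturated chain carbon, three bonds along the chain from an aromatic nitrogen. The steps that enlarge the chain on the aromatic nitrogen, from compound 1 and from compound 2 to compound 3, bear on this change, and none of them moved this assay beyond the scatter. Compound 4 is therefore expected to show a 1.1-fold higher number from compound 3 to compound 4 (0.02 log units; within the scatter), no step beyond the scatter. The estimate for compound 4 in this assay is 7.5 nM, expected between 3.5 nM and 16 nM.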

Compound 4, half-maximal inhibitory concentration: 21 nM
Compound 4: middle estimate off by 2.8-fold (0.45 log units), on the low side; the measured number lies above the stated range.
By their numbers in this assay, from the lowest: compounds 3, 2 and 1 (each within the scatter of the next); then compound 4.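

In this assay, within the data shown here, 1-butylpentyl is the only group on the aromatic nitrogen that moves the number beyond the scatter, with a 3.0-fold higher number from compound 3 to compound 4 (0.47 log units; beyond the scatter) and a 2.9-fold higher number from compound 2 to compound 4 (0.46 log units; beyond the scatter) and a 2.7-fold higher number from compound 1 to compound 4 (0.43 log units; beyond the scatter) as the steps to it. This position therefore does not accept every enlargement equally: 1-methylbutyl, 1-isopropylbutyl and 1-ethylpentyl stay within the scatter of one another, while ethyl in place of hydrogen, three bonds along the chain, does not. No available evidence accounts for this shift.

From the compounds shown here alone, whether a longer chain such as 1-pentylhexyl raises the number further remains open. So does the effect of a hydroxyl or an amine at the end of the butyl chain.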